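Lengthening the Ether Side Chain of a Stilbene

This account rests on a few compounds, and the source may have more. Where it says the series, first, only, none or still open, it means among the compounds named here.

Compound 1 `COc1ccc(/C=C\c2cc(OC)c(OC)c(OC)c2)cc1OCc1ccc(Br)cc1` gives 45000 nM in an ADME assay on HEK293 cells (Homo sapiens) for inhibition, read by MTT assay, with a stated time of 3 days (a lower number here means a stronger inhibitor, a higher number a weaker inhibitor), the lowest of the two numbers measured. Compound 2 `COc1ccc(/C=C\c2cc(OC)c(OC)c(OC)c2)cc1OCCC/C=C/c1ccc(Cl)cc1` gives 111000 nM; the step of a 2.5-fold higher number from compound 1 to compound 2 (0.39 log units; beyond the scatter) is modest but beyond the usual scatter. Compound 3 `COc1ccc(/C=C\c2cc(OC)c(OC)c(OC)c2)cc1OCCC/C=C/c1ccc(Br)cc1` differs from compound 1 by a group of 11 heavy atoms (10 carbon, 1 bromine; one six-membered aromatic ring of carbon only) in place of a group of 7 heavy atoms (6 carbon, 1 bromine; one six-membered aromatic ring of carbon only), on a saturated chain carbon bound to an oxygen on an aromatic ring. This change mirrors the step from compound 1 to compound 2, with bromine kept in place of chlorine, so a similar weakening is expected, estimated as a 2.2-fold higher number from compound 1 to compound 3 (0.35 log units; beyond the scatter). Compound 3 is therefore expected to give about 100000 nM, with a likely range from 40000 nM to 250000 nM.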

Compound 3, half-maximal inhibitory concentration: 55000 nM
The estimate for compound 3 lay 1.8-fold (0.26 log units) above the measured number, and the stated range covers the measured number.
By their numbers in this assay, from the lowest: compounds 1, 3 and 2 (each within the scatter of the next, the first and the last beyond it).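

In this assay, the longer group in place of 4-bromophenyl gives a 1.2-fold higher number from compound 1 to compound 3 (0.09 log units; within the scatter), so with bromine kept, lengthening the side chain leaves no change that can be told from the scatter. Bromo in place of chloro on an aromatic carbon gives a 2.0-fold lower number from compound 2 to compound 3 (0.30 log units; within the scatter), which also lies within the scatter, so this assay does not separate the two halogens on the longer chain. No further measurement is at hand to explain these numbers. From the compounds shown here alone, what remains open is whether an amine or a carboxylic acid at the end of the chain would move the number beyond the scatter.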